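Sulfonyl aryl variation: chloro to bromo at the para position

The source may hold more compounds than are shown below. What is called first, only, known or untested is meant among the compounds shown, and "the series" means these compounds.

Three compounds of the shared core differ only in the aryl on the sulfonyl sulfur. Compound 1 `CCCc1nc2c(C)cc(-c3nc4ccccc4n3C)cc2n1S(=O)(=O)c1c(C)cc(C)cc1C` in a functional assay on A549 cells (Homo sapiens) for cytotoxicity, read by MTT assay (on this read-out lower numbers stand for stronger inhibition and higher numbers for weaker inhibition), gives a value that is a limit of the assay, > 50000 nM. Compound 2 `CCCc1nc2c(C)cc(-c3nc4ccccc4n3C)cc2n1S(=O)(=O)c1ccc(OC)cc1` in this assay gives 34700 nM. Compound 3 `CCCc1nc2c(C)cc(-c3nc4ccccc4n3C)cc2n1S(=O)(=O)c1ccc(Cl)cc1` in this assay gives a value that is likewise a limit of the assay, > 50000 nM. Two of the three values sit at that same limit (the limit of > 50000 nM in this assay, at which 2 of the 3 values shown sit), so compound 3 stands at the ceiling of what the assay reports rather than at a number. The measured steps are an at least 1.4-fold lower number from compound 1 to compound 2 (0.15 log units; that floor lies within the scatter), a step that the two limits leave unreadable from compound 1 to compound 3 and an at least 1.4-fold higher number from compound 2 to compound 3 (0.15 log units; that floor lies within the scatter); the first two rest on a limit and the third is at its floor within the scatter.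

Compound 4 `CCCc1nc2c(C)cc(-c3nc4ccccc4n3C)cc2n1S(=O)(=O)c1ccc(Br)cc1` arises from compound 3 by bromo in place of chloro on an aromatic carbon. Going by the values given here, the only step that touches the same position, the chloro in place of methoxy from compound 2 to compound 3, is itself not readable beyond the scatter, and no measured step covers bromo for chloro. The expectation is therefore no step beyond the scatter, a step that the limit leaves unreadable from compound 3 to compound 4, with a limit again likely. Compound 4 is estimated at 60000 nM, within 25000 nM to 150000 nM.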

Compound 4, half-maximal inhibitory concentration: 35100 nM
The estimate for compound 4 lay 1.7-fold (0.23 log units) above the measured number; the range from low to high includes it.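

With bromo para to a large group, this position gives a second readable number in this assay, level with the methoxy compound: a 1.0-fold higher number from compound 2 to compound 4 (0.00 log units; within the scatter). Bromo in place of chloro reads as an at least 1.4-fold lower number from compound 3 to compound 4 (0.15 log units; that floor lies within the scatter), and 4-bromophenyl in place of 2,4,6-trimethylphenyl reads as an at least 1.4-fold lower number from compound 1 to compound 4 (0.15 log units; that floor lies within the scatter). Both of these steps rest on a limit, so their full sizes stay unknown and neither is shown to go beyond the scatter: the limit of > 50000 nM in this assay, at which 2 of the 4 values shown sit.

From the compounds shown here alone, whether chloro and bromo differ at all at this position stays open while compound 3 remains a limit of the assay. Also open, going by these compounds, is how an amine or a carboxylic acid on the sulfonyl aryl, or a longer chain in place of the propyl on the shared core, would read in this assay.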